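Iodo for Ethoxy on the Fused Core: Compound 4

The source may hold more compounds than are shown below. What is called first, only, known or untested is meant among the compounds shown, and "the series" means these compounds.

Measured so far:
compound 1 `CCOc1nc(CC)n2c1C(CCc1ccc(C(F)(F)F)cc1)N([C@@H](C(=O)NC)c1ccccc1)CC2` gives 2750 nM;
compound 2 `CNC(=O)[C@@H](c1ccccc1)N1CCn2c(CC3CC3)nc(Cl)c2[C@@H]1CCc1ccc(C(F)(F)F)cc1` gives 35 nM;
compound 3 `CNC(=O)[C@@H](c1ccccc1)N1CCn2c(C)nc(Cl)c2[C@@H]1CCc1ccc(C(F)(F)F)cc1` gives 13 nM, all in a functional assay on CHO cells for antagonist activity at Orexin receptor type 2 (Homo sapiens), read by FLIPR and calcium flux; on this read-out higher numbers stand for weaker inhibition and lower numbers for stronger inhibition.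

Compound 1 gives the highest number of the three; compounds 2 and 3, which carry chloro where compound 1 carries ethoxy but differ from it in a second place too, give far lower numbers. Going by the values given here, the only single-place step, a 2.7-fold lower number from compound 2 to compound 3 (0.43 log units; beyond the scatter), does not touch the ethoxy position. Compound 4 `CCc1nc(I)c2n1CCN([C@@H](C(=O)NC)c1ccccc1)C2CCc1ccc(C(F)(F)F)cc1` arises from compound 1 by iodo in place of ethoxy on an aromatic carbon. Among the compounds with values here, no measured step covers this exact change; the expectation rests on the low numbers of the chloro-bearing compounds 2 and 3, so a large drop is expected, a 46-fold lower number from compound 1 to compound 4 (1.66 log units; beyond the scatter). Compound 4 is estimated at 60 nM, between 15 nM and 250 nM.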

Compound 4, half-maximal inhibitory concentration: 23 nM
Beside the measured number, compound 4's estimate is 2.6-fold (0.42 log units) above it, within the range that was stated.
By their numbers in this assay, from the lowest: compounds 3, 4 and 2 (each within the scatter of the next, the first and the last beyond it); then compound 1.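

a 120-fold lower number from compound 1 to compound 4 (2.08 log units; beyond the scatter) in this assay is a single-place change of iodo in place of ethoxy, with the ethyl group and the rest of the core held constant. The earlier compounds shown here could not separate this position from a second difference, whereas this step shows that the group here alone can move the number by a large amount. Nothing measured here explains the size of this step.

Iodo and chloro still lack a matched pair, as compound 4 and compounds 2 and 3 differ in two places. From the compounds shown here alone, how methoxy, an amine or a nitrile would read at this position remains open.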